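The source may report more compounds than this note shows. Statements on the series, on what has been measured and on what is new or still open speak of the compounds shown alone.

The compounds here share one core, and what varies is the group carried on the amide nitrogen. In a functional assay on A549 cells (Homo sapiens) for inhibition, read by MTT assay, with a stated time of 48 h (a higher number here means a weaker inhibitor, a lower number a stronger inhibitor), compound 2 `COc1ccc2c(=O)c(/C=C/C(=O)NCc3ccccc3)coc2c1` gives 11800 nM, the lowest of the two numbers recorded so far. Compound 3 `COc1ccc(NC(=O)/C=C/c2coc3cc(O)ccc3c2=O)cc1` gives 12800 nM in this assay, which puts it and compound 2 within the usual scatter of repeated measurements of one another. Compound 1 `COc1ccc(CNC(=O)/C=C/c2coc3cc(O)ccc3c2=O)cc1` reaches only a limit of this assay, > 100000 nM, and that reading is a limit rather than a number; (the limit of > 100000 nM in this assay, at which 1 of the 3 values shown sits). Compound 1 and compound 3 share the same core, and their two readings show a limit for compound 1 and a number for compound 3.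

The new compound, compound 4 `COc1ccc2c(=O)c(/C=C/C(=O)Nc3ccccc3OC)coc2c1`, differs from compound 2 in one place: 2-methoxyphenyl in place of benzyl on an amide-type nitrogen. Going by the values given here, no pair of measured compounds differs by exactly this change, so the size of the step is not known in advance. The expectation is for a small shift, from compound 2 to compound 4 an estimated 1.3-fold lower number from compound 2 to compound 4 (0.12 log units; within the scatter), which stays within the scatter. Compound 4 is expected to give about 9000 nM in this assay, with a likely range from 2500 nM to 35000 nM.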

Compound 4, half-maximal inhibitory concentration: > 100000 nM
Compound 4: no number, only a limit; the forecaster's own chance of this, stated with the estimate: 10%; middle value at least 11-fold (1.04 log units) away from the limit.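

In this assay, going by these compounds alone, replacing benzyl with 2-methoxyphenyl on the amide-type nitrogen gives an at least 8.4-fold higher number from compound 2 to compound 4 (0.92 log units; beyond the scatter), the first readable step in this set between two compounds that differ in one place. The step lies beyond the usual scatter, so the group on this nitrogen is not a free choice: with the rest of the molecule held constant, this single swap is enough to lose a measurable value. Compound 4 gives only a limit and not a number, so the true size of the step stays unknown, and such readings make up a large share of this small set: the limit of > 100000 nM in this assay, at which 2 of the 4 values shown sit.

The swap changes two things at once, how the aromatic ring is joined to the nitrogen and the presence of a methoxy group, and the compounds shown cannot say which of them matters. As far as these compounds go, a plain phenyl group on the same nitrogen, with no methoxy group, would pull these two changes apart, and whether it keeps a measurable value remains open.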